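The compounds below may be only part of what the source reports. "The series", "measured", "known", "first", "only" and "open" are said of these compounds alone.

Measured compounds:
- compound 1 `Nc1ccccc1NC(=O)c1ccc(CSC(=S)N2CCN(c3cccnc3)CC2)cc1` with 40.5%
- compound 2 `CC1CCCCN1C(=S)SCc1ccc(C(=O)Nc2ccccc2N)cc1` with 42.5%
- compound 3 `N#Cc1ccc(N2CCN(C(=S)SCc3ccc(C(=O)Nc4ccccc4N)cc3)CC2)cc1` with 41.4%

In a functional assay on A-375 cells (Homo sapiens) for antiproliferative activity, read by CCK-8 assay, with a stated time of 72 h, tested at 2 uM (a higher number here means a stronger effect of the compound at the concentration tested, a lower number a weaker effect), the three compounds give numbers that sit close together. Compound 1 gives 40.5% in this assay, and its gap to compound 3 is a number 0.9 percentage points higher from compound 1 to compound 3 (within the scatter), while compound 2 gives a number that is also within the scatter of compound 1. Among the compounds with values here, no compound therefore stands apart from the others in this assay.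

The unmeasured compound 4 `CN1CCN(C(=S)SCc2ccc(C(=O)Nc3ccccc3N)cc2)CC1` differs from compound 1 in one place: methyl in place of pyridin-3-yl on an amine nitrogen in a ring. Within the data shown here, only one measured step touches the same amine nitrogen in a ring, the swap of pyridin-3-yl for 4-cyanophenyl, which gave a change of a number 0.9 percentage points higher from compound 1 to compound 3 (within the scatter) and so lay within the scatter. Among the measured compounds shown here, that step exchanged one six-membered aromatic ring for another; no measured pair shows a methyl entering at this amine nitrogen in a ring in place of an aromatic ring, so the present change has no direct precedent in the data. Since the one replacement at this position, from compound 1 to compound 3, moved the number by only a number 0.9 percentage points higher from compound 1 to compound 3 (within the scatter), a step in this assay that stays within the scatter is expected for compound 4, with no clear direction. Compound 4 is estimated to give 38% in this assay, within a range from 27% to 49%, which corresponds to an expected step of a number 2.5 percentage points lower from compound 1 to compound 4 (within the scatter).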

Compound 4, a percentage reported as inhibition, at one concentration (the size of the read-out at that concentration, not a potency): 36.6%
Compound 4: middle estimate off by 1.4 percentage points, on the high side; the range from low to high includes it.
By their numbers in this assay, from the lowest: compounds 4, 1, 3 and 2 (each within the scatter of the next).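

Within the data shown here, until this result, the amine nitrogen in the ring had carried only six-membered aromatic rings. With methyl, a single carbon and no ring, in that place, this assay shows a number 3.9 percentage points lower from compound 1 to compound 4 (within the scatter), and methyl in place of 4-cyanophenyl gives a number 4.8 percentage points lower from compound 3 to compound 4 (within the scatter), so among these compounds the aromatic ring at this position can be lost without a step beyond the scatter. The change of the whole amine on the thiocarbonyl carbon, 4-methylpiperazin-1-yl in place of 2-methylpiperidin-1-yl, also stays inside that limit, with a number 5.9 percentage points lower from compound 2 to compound 4 (within the scatter), and no measurement at hand offers an explanation for any of these results.

What the compounds shown leave open is whether this flat picture would hold with an ethyl group, a longer chain, a primary amine or a carboxylic acid on the same ring nitrogen. They also leave open whether compounds that cannot be told apart in this read-out at one concentration would differ in potency, since a single-concentration number does not give one.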